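Bromo for ethoxy: expected value for compound 4

The compounds below may be only part of what the source reports. "The series", "measured", "known", "first", "only" and "open" are said of these compounds alone.

Measured compounds, numbers from a functional assay on HeLa cells (Homo sapiens) for inhibition, read by sulforhodamine B assay; a higher number here means a weaker inhibitor, a lower number a stronger inhibitor:
- compound 1 `CCOc1ccc(NC2=CC(=O)c3c(nc4n3[C@H]3OC[C@@H](O)[C@H]3OC4)C2=O)cc1` gives 14400 nM
- compound 2 `O=C1C=C(Nc2ccccc2)C(=O)c2c1nc1n2[C@H]2OC[C@@H](O)[C@H]2OC1` gives 5620 nM
- compound 3 `O=C1C=C(NC2CCCCC2)C(=O)c2c1nc1n2[C@H]2OC[C@@H](O)[C@H]2OC1` is recorded only as a limit of the assay, > 16000 nM

Compound 3 sits at the limit of > 16000 nM in this assay, at which 1 of the 3 values shown sits, so no number is known for it. Among the two numbers available, compound 1 carries the higher one, and compound 2 is the nearest with a lower number. Among the compounds with values here, the only one-place step recorded is an at least 2.8-fold higher number from compound 2 to compound 3 (0.45 log units; beyond the scatter), which concerns the group on the amine nitrogen and not the substituent of the aromatic ring.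

Compound 4 `O=C1C(Nc2ccc(Br)cc2)=CC(=O)c2c1nc1n2[C@H]2OC[C@@H](O)[C@H]2OC1` differs from compound 1 by bromo in place of ethoxy on an aromatic carbon. Within the data shown here, no measured step covers this change. The comparison of compound 1 with compound 2 shows that the ethoxy group, set against the unsubstituted phenyl, goes with the higher number; a bromo group on the same aromatic carbon has not been tested in this set. Compound 4 is therefore expected to land between the two, with the step of a 1.6-fold lower number from compound 1 to compound 4 (0.20 log units; within the scatter) expected to point downward and to remain modest. The estimate for compound 4 is 9000 nM, with a range from 3500 nM to 22000 nM.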

Compound 4, half-maximal inhibitory concentration: 5220 nM
The estimate for compound 4 lay 1.7-fold (0.24 log units) above the measured number, within the range that was stated.
By their numbers in this assay, from the lowest: compounds 4 and 2 (each within the scatter of the next); then compound 1. At a limit, above all of these: compound 3.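

In this assay, within the data shown here, the step of a 2.8-fold lower number from compound 1 to compound 4 (0.44 log units; beyond the scatter) is the first recorded change at this aromatic carbon, para to a large group, and it shows that the number responds to the group placed there and not only to the group on the amine nitrogen. Compound 4 gives 5220 nM and compound 2 gives 5620 nM, two values within the scatter of each other, so in this series the bromo compound and the unsubstituted phenyl compound cannot be told apart, while compound 1, with its 4-ethoxyphenyl group, stands apart from both with a higher number. Nothing recorded for these compounds bears on the cause of this step.

As far as these compounds go, with only ethoxy, bromo and the unsubstituted ring at this carbon, the series gives three points and no trend, and it remains open whether the higher number belongs to ethoxy alone or extends to other groups joined through oxygen, such as methoxy or a longer alkoxy chain. Also open, from the compounds shown here alone, is where a chloro, an amine or a carboxylic acid on the same carbon would fall relative to compounds 1, 2 and 4.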